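Inverting One Stereocentre on the Amine Substituent

The compounds below may be only part of what the source reports. "The series", "measured", "known", "first", "only" and "open" are said of these compounds alone.

Compound 2 `O[C@@H]1[C@H](O)[C@@H]2C[C@@H]2[C@H]1n1cnc2c(N[C@@H](C3CCC3)C3CC3)nc(Cl)nc21` stands, in an assay on CHO cells for displacement of a labelled ligand from adenosine receptor A1 (Homo sapiens), read by ERK phosphorylation, with a stated time of 60 min (on this read-out higher numbers stand for weaker inhibition and lower numbers for stronger inhibition), at 270 nM, the lowest of the two numbers recorded so far. Compound 1 `O[C@@H]1[C@H](O)[C@@H]2C[C@@H]2[C@H]1n1cnc2c(NCC(C3CC3)C3CC3)nc(Cl)nc21` gives 780 nM in this assay, and the step of a 2.9-fold lower number from compound 1 to compound 2 (0.46 log units; beyond the scatter) accompanies cyclobutyl(cyclopropyl)methyl in place of 2,2-dicyclopropylethyl on the nitrogen on the aromatic ring. Compound 3 `O[C@@H]1[C@H](O)[C@@H]2C[C@@H]2[C@H]1n1cnc2c(N[C@H](C3CCC3)C3CC3)nc(Cl)nc21` now follows: the two compounds have the same atoms and bonds and differ only in configuration as drawn: 1 of 6 stereo elements differ; a stereocentre at a saturated chain carbon is drawn R in compound 2 and S in compound 3. Among the measured compounds shown here, no measured step bears directly on such an inversion, since the only step at hand concerns a change of the group rather than its configuration, so the size of the step can only be guessed. Because compound 2 already holds the lowest number with 270 nM, the drawn mirror arrangement at that centre is estimated to give a modest weakening, a 3.3-fold higher number from compound 2 to compound 3 (0.52 log units; beyond the scatter), with wide uncertainty. Compound 3 is therefore expected to give about 900 nM in this assay, between 250 nM and 3500 nM.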

Compound 3, inhibition constant: 120 nM
Compound 3: the middle estimate sits 7.5-fold (0.88 log units) above what was measured; the measured number lies below the stated range.
By their numbers in this assay, from the lowest: compound 3; then compound 2; then compound 1.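

The stereocentre at the saturated chain carbon of the cyclobutyl(cyclopropyl)methyl group matters in this assay, and the S drawing gives the lower number, with a 2.3-fold lower number from compound 2 to compound 3 (0.35 log units; beyond the scatter). With that drawing, cyclobutyl(cyclopropyl)methyl in place of 2,2-dicyclopropylethyl gives a 6.5-fold lower number from compound 1 to compound 3 (0.81 log units; beyond the scatter), so the earlier step with the R drawing did not show the full size of this change. The gap between the two mirror arrangements can be assigned to that one carbon alone, since nothing else differs: the fact that compounds 2 and 3 differ only in the configuration as drawn

The compounds shown leave open whether the S drawing stays favoured when the cyclobutyl group gives way to a cyclopentyl or phenyl group. They also leave open how the two arrangements compare at other adenosine receptors.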